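Triazole-linked amides: aryl variation on triazole nitrogen

A few compounds are considered here, and "the series" means these few. Any claim that something is new, unique, unknown or untested is made for them only; others in the source may bear on it.

Measured so far:
Compound 1, `Cc1ccc(-n2cc(CNC(=O)c3cccc4c3cnn4C(C)C)nn2)cc1C`. In a functional assay on MCF7 cells (Homo sapiens) for inhibition, read by MTT assay, with a stated time of 72 h (a higher number here means a weaker inhibitor, a lower number a stronger inhibitor), compound 1 gives only a limit, > 40000 nM.
Compound 2, `CC(C)n1ncc2c(C(=O)NCc3cn(-c4cccc(F)c4)nn3)cccc21`. In this assay compound 2 gives only a limit, > 40000 nM.
Compound 3, `Cc1cccc(-n2cc(CNC(=O)c3cccc4c3cnn4C(C)C)nn2)c1`. In this assay compound 3 gives only a limit, > 40000 nM.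

Compound 3 therefore stands nowhere in particular: its value is a limit of this assay, and the two other values are limits as well, so no order among the three can be read. The steps among them are likewise unreadable: a step that the two limits leave unreadable from compound 1 to compound 2, a step that the two limits leave unreadable from compound 1 to compound 3 and a step that the two limits leave unreadable from compound 2 to compound 3. The only firm point is the limit of > 40000 nM in this assay, at which 3 of the 3 values shown sit.

Compound 4, `CC(C)n1ncc2c(C(=O)NCc3cn(-c4ccc(C(F)(F)F)cc4)nn3)cccc21`, differs from compound 3 in one place: 4-(trifluoromethyl)phenyl in place of 3-methylphenyl on an aromatic nitrogen. For the measured compounds named here, every measured change of the aryl group on that nitrogen has left the value at the limit, so no measured step gives a direction or a size for this one. The expectation for this assay is no step beyond the scatter that can be read, with the result most probably again a limit. Compound 4 is expected at 40000 nM, within 15000 nM to 100000 nM. The expected step is a number no higher from compound 3 to compound 4 (the limit leaves the size open).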

Compound 4, half-maximal inhibitory concentration: > 40000 nM
Compound 4 was reported as a limit; the forecaster's own chance of this, stated with the estimate: 85%; the middle value lies on the limit itself.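

In this assay compound 4 gives only a limit, > 40000 nM. The steps from compound 1, compound 2 and compound 3 to compound 4 cannot be read, and the only firm point remains: the limit of > 40000 nM in this assay, at which 4 of the 4 values shown sit. The compounds shown leave open whether any aryl group on that aromatic nitrogen gives a readable value in this assay, and in which direction such a change would go.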